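This account rests on a few compounds, and the source may have more. Where it says the series, first, only, none or still open, it means among the compounds named here.

Working notes on the hydrazone series around a shared core.

Compound 3 `Cc1cc(C)c(/C=N/Nc2ncc3c(n2)n(C2CCCC2)c(=O)c(=O)n3C)c(C)c1` gives 13900 nM in a functional assay on PC-3 cells (Homo sapiens) for antiproliferative activity, read by MTT assay; on this read-out lower numbers stand for stronger inhibition and higher numbers for weaker inhibition. Compound 2 `Cn1c(=O)c(=O)n(C2CCCC2)c2nc(N/N=C/c3ccc(C(F)(F)F)cc3)ncc21` gives 23600 nM in this assay, and a 1.7-fold lower number from compound 2 to compound 3 (0.23 log units; within the scatter). Compound 1 `Cn1c(=O)c(=O)n(C2CCCC2)c2nc(N/N=C/c3ccc(O)cc3)ncc21` returns only a limit in this assay, > 100000 nM (the limit of > 100000 nM in this assay, at which 1 of the 3 values shown sits). Measured against that limit, an at least 4.2-fold lower number from compound 1 to compound 2 (0.62 log units; beyond the scatter) and an at least 7.1-fold lower number from compound 1 to compound 3 (0.85 log units; beyond the scatter). Among the two numbers shown, compound 3 carries the lowest, with compound 2 nearest and within the scatter of it.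

Compound 4 `COc1ccc(/C=N/Nc2ncc3c(n2)n(C2CCCC2)c(=O)c(=O)n3C)cc1` has not yet been measured in this assay. Its difference from compound 3: 4-methoxyphenyl in place of 2,4,6-trimethylphenyl on a carbon with a double bond to nitrogen. For the measured compounds named here, no measured step swaps exactly these two groups, so the aryl swaps above are the only guide: the larger of them is an at least 7.1-fold lower number from compound 1 to compound 3 (0.85 log units; beyond the scatter), the smaller 1.7-fold lower number from compound 2 to compound 3 (0.23 log units; within the scatter). A step beyond the scatter towards a higher number is expected, a 2.5-fold higher number from compound 3 to compound 4 (0.40 log units; beyond the scatter), though short of the limit seen for compound 1. The estimate for compound 4 is 35000 nM, with a range from 9000 nM to 150000 nM.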

Compound 4, half-maximal inhibitory concentration: 26300 nM
Compound 4: the middle estimate sits 1.3-fold (0.12 log units) above what was measured; low and high end bracket the measured number.
By their numbers in this assay, from the lowest: compounds 3, 2 and 4 (each within the scatter of the next). At a limit, above all of these: compound 1.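

On the carbon with a double bond to nitrogen, 4-methoxyphenyl does not separate from either earlier group: a 1.9-fold higher number from compound 3 to compound 4 (0.28 log units; within the scatter), and a 1.1-fold higher number from compound 2 to compound 4 (0.05 log units; within the scatter). Compounds 2, 3 and 4 therefore form one group in this assay despite their different aryl substituents, and compound 1 is the only one shown that goes against this, while methyl in place of hydrogen on an oxygen on an aromatic ring gives an at least 3.8-fold lower number from compound 1 to compound 4 (0.58 log units; beyond the scatter). Compound 1 stands at a limit, so that step gives a bound and not a size: the limit of > 100000 nM in this assay, at which 1 of the 4 values shown sits.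

As far as these compounds go, whether an amine or a carboxylic acid on the aromatic ring would track compound 1 or the other three remains open. All the compounds shown keep an aromatic ring at this place, so the outcome with a saturated group such as cyclohexyl cannot be read.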